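Methylamino to Ethylamino: One Step Measured, One Expected

This account rests on a few compounds, and the source may have more. Where it says the series, first, only, none or still open, it means among the compounds named here.

In a functional assay on HCT-8 cells (Homo sapiens) for antiproliferative activity, read by MTT assay, with a stated time of 48 h (on this read-out higher numbers stand for weaker inhibition and lower numbers for stronger inhibition), compound 1 `CNCC(=O)Nc1cc(OC)ccc1C(=O)c1ccc(OC)c2c1OC(C)(C)C=C2` gives 740 nM. Compound 2 `CCNCC(=O)Nc1cc(OC)ccc1C(=O)c1ccc(OC)c2c1OC(C)(C)C=C2` carries one change, (methyl in place of hydrogen on a saturated chain carbon bound to an amine nitrogen), and gives 3690 nM; that change made a 5.0-fold higher number from compound 1 to compound 2 (0.70 log units; beyond the scatter). Compound 3 `C=C(c1ccc(OC)cc1NC(=O)CNC)c1ccc(OC)c2c1OC(C)(C)C=C2` is built on a different core; the difference between the two cores is not broken down here. In this assay compound 3 gives 320 nM, the lowest of the three numbers. Compound 4 `C=C(c1ccc(OC)cc1NC(=O)CNCC)c1ccc(OC)c2c1OC(C)(C)C=C2` carries the same kind of change relative to compound 3, namely (methyl in place of hydrogen on a saturated chain carbon bound to an amine nitrogen), at the same place as before. Because the earlier step of a 5.0-fold higher number from compound 1 to compound 2 (0.70 log units; beyond the scatter) was a modest weakening, a step of similar size is expected here, a 5.0-fold higher number from compound 3 to compound 4 (0.70 log units; beyond the scatter). On that basis compound 4 is estimated at 1600 nM, most likely between 600 nM and 4500 nM.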

Compound 4, half-maximal inhibitory concentration: 1380 nM
For compound 4 the middle estimate is 1.2-fold (0.06 log units) above the measured one; measured number inside the range.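

In this assay, replacing methylamino with ethylamino on the second core again gives a weaker result, a 4.3-fold higher number from compound 3 to compound 4 (0.63 log units; beyond the scatter). The change therefore carries over between these two cores at about the same size: the same change on two cores in this assay, a 5.0-fold higher number (0.70 log units; beyond the scatter) from compound 1 to compound 2 and a 4.3-fold higher number (0.63 log units; beyond the scatter) from compound 3 to compound 4, 1.2-fold (0.06 log units) apart, within the scatter of two such steps. For the compounds shown here, this agreement rests on only two cores and one small change, so it does not show that the step would hold on other cores, nor does it explain why the ethylamino compounds give higher numbers.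

The compounds shown leave open whether a longer chain, such as propylamino, would raise the number further. They also leave open how a primary amine or a ring amine such as pyrrolidine would compare at the same place.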